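Carbamoyl-to-thio replacement: cytotoxicity limits in the series

The compounds below may be only part of what the source reports. "The series", "measured", "known", "first", "only" and "open" are said of these compounds alone.

Three compounds of the series have been run in an ADME assay on Vero cells (Chlorocebus sabaeus) for cytotoxicity, read by MTT assay, with a stated time of 96 h; on this read-out higher numbers stand for lower toxicity in this test and lower numbers for higher toxicity in this test. Compound 1 `C/C(=N\NC(N)=O)c1ccc2[nH]c(-c3ccc(Cl)cc3)nc2c1` gives > 100000 nM, which is a limit of the assay rather than a number. Compound 2 `C/C(=N\NC(N)=S)c1ccc2[nH]c(-c3ccc(Cl)cc3)nc2c1` gives > 100000 nM, again a limit. Compound 3 `C/C(=N\NC(N)=O)c1ccc2c(c1)nc(-c1ccccc1)n2C1CCCCC1` gives > 100000 nM, also a limit. Between compound 1 and compound 2 the change is a group of 3 heavy atoms (1 carbon, 1 nitrogen, 1 sulfur; no ring) in place of a group of 3 heavy atoms (1 carbon, 1 nitrogen, 1 oxygen; no ring), on an amine nitrogen and in this assay it made a step that the two limits leave unreadable from compound 1 to compound 2. Going by the values given here, the only thing the measured pair shows is the limit of > 100000 nM in this assay, at which 3 of the 3 values shown sit. The difference between the core of compound 1 and the core of compound 3 is not broken down here.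

Compound 4 `C/C(=N\NC(N)=S)c1ccc2c(c1)nc(-c1ccccc1)n2C1CCCCC1` has not yet been measured. It differs from compound 3 by a group of 3 heavy atoms (1 carbon, 1 nitrogen, 1 sulfur; no ring) in place of a group of 3 heavy atoms (1 carbon, 1 nitrogen, 1 oxygen; no ring), on an amine nitrogen, the same kind of change as that from compound 1 to compound 2, at a place described in the same words. The expected step from compound 3 to compound 4 in this assay is a number no higher from compound 3 to compound 4 (the limit leaves the size open), and this rests on (the limit of > 100000 nM in this assay, at which 3 of the 3 values shown sit), at which every value shown so far sits. Compound 4 is therefore estimated at 100000 nM, most probably returned as a limit once more.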

Compound 4, half-maximal cytotoxic concentration: 20000 nM
The estimate for compound 4 lay 5.0-fold (0.70 log units) above the measured number, outside the stated range (below it).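

On the core of compound 3, carbamoyl replaced by the sulfur-bearing group on an amine nitrogen gives an at least 5.0-fold lower number from compound 3 to compound 4 (0.69 log units; beyond the scatter) in this assay, and a lower number here stands for higher toxicity in this test. Compound 2 gives > 100000 nM, which is a limit, and a single readable step on a single core sets no rule for the series. The same change on the core of compound 1 cannot be read, so whether the step carries over between the two cores, or differs in size, is not shown, since the values there give no number: the limit of > 100000 nM in this assay, at which 3 of the 4 values shown sit.

Open, on these data alone, is whether an acetyl group or a sulfonamide on that amine nitrogen would stay with compound 3 or move with compound 4. Also open is which part of the difference between the core of compound 1 and the core of compound 3 goes with a readable number, as no compound shown separates the two.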